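The source may hold more compounds than are shown below. What is called first, only, known or untested is meant among the compounds shown, and "the series" means these compounds.

Among the compounds with values here, in a functional assay on HeLa cells (Homo sapiens) for inhibition, read by CCK-8 assay, with a stated time of 48 h (on this read-out higher numbers stand for weaker inhibition and lower numbers for stronger inhibition), compound 1 `O=C(NCCNS(=O)(=O)c1ccc(-c2ccccc2O[C@H]2CC[C@H](O)CC2)s1)Nc1ccc([N+](=O)[O-])cc1` gives 10500 nM as the only exact number so far. Compound 2 `O=C(NCCNS(=O)(=O)c1ccc(-c2ccccc2Oc2ccc(O)c(O)c2)s1)Nc1cc(Cl)cc(Cl)c1` gives > 20000 nM as a limit and not a number. Compound 3 `COc1cccc(NC(=S)NCCNS(=O)(=O)c2ccc(-c3ccccc3Oc3ccc([N+](=O)[O-])cc3)s2)c1` gives > 50000 nM as a limit too. Compound 4 `O=C(NCCNS(=O)(=O)c1ccc(-c2ccccc2OCc2ccccc2)s1)Nc1cc(Cl)cc(Cl)c1` differs from compound 2 in one place. The change is benzyl in place of 3,4-dihydroxyphenyl on an oxygen on an aromatic ring. Within the data shown here, no measured pair shows this change, and compound 1 at 10500 nM is the one firm reference. The expected step is an at least 1.4-fold lower number from compound 2 to compound 4 (0.15 log units; that floor lies within the scatter) in the direction of stronger inhibition and of modest size. Compound 4 is estimated at 14000 nM with an expected range of 5000 nM to 35000 nM and a limit reading stays possible.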

Compound 4, half-maximal inhibitory concentration: > 20000 nM
Compound 4: a limit, no number; the forecaster's own chance of this, stated with the estimate: 35%; middle value at least 1.4-fold (0.15 log units) away from the limit.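

In this assay compound 4 gives > 20000 nM, a limit like that of compound 2, so no step can be read between compound 2 and compound 4. On these data alone, whether benzyl or 3,4-dihydroxyphenyl on that oxygen gives stronger inhibition stays open.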